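The source may report more compounds than this note shows. Statements on the series, on what has been measured and on what is new or still open speak of the compounds shown alone.

Of the compounds shown here, three that share one core have been tested in a functional assay on KB cells (Homo sapiens) for cytotoxicity; on this read-out higher numbers stand for an effect only at larger amounts of compound and lower numbers for an effect already at smaller amounts. Compound 1, `CCC[C@@H](OC(C)=O)C1=C(Br)[C@@](C)(OC)OC1=O`, gives 2.8 ug/mL. Compound 3, `CCC[C@@H](OC(C)=O)C1=C(Br)[C@@](OC)(C(Br)Br)OC1=O`, gives 6.2 ug/mL. Compound 2, `CCCCC1=C(Br)/C(=C/Br)OC1=O`, reaches only a limit of the assay in this assay, namely > 20 ug/mL. Compound 2 therefore stands at the limit of > 20 ug/mL in this assay, at which 1 of the 3 values shown sits, not at a number.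

Compound 4, `CCC[C@@H](O)C1=C(Br)/C(=C/Br)OC1=O`, has not yet been measured in this assay. It differs from compound 2 in one place: hydroxy in place of hydrogen on a saturated chain carbon bound to a double-bonded ring carbon and a saturated chain carbon. Among the measured compounds shown here, because compound 2 sits at the limit of > 20 ug/mL in this assay, at which 1 of the 3 values shown sits, no measured step fixes what this change does, and compound 1 and compound 3 differ from compound 4 in more than one place, so their values serve only as loose context. The expectation for compound 4 in this assay is 12 ug/mL, within a range from 3 ug/mL to 40 ug/mL. The step that this estimate means is expected to be an at least 1.6-fold lower number from compound 2 to compound 4 (0.22 log units; that floor lies within the scatter), toward an effect at smaller amounts than the limit, though with a real chance that again only a limit is found.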

Compound 4, concentration for half-maximal effect: 0.1 ug/mL
Beside the measured number, compound 4's estimate is 120-fold (2.08 log units) above it; the whole stated range lies above it.
By their numbers in this assay, from the lowest: compound 4; then compound 1; then compound 3. At a limit, above all of these: compound 2.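

In this assay, hydroxy in place of hydrogen on a saturated chain carbon bound to a double-bonded ring carbon and a saturated chain carbon brings an at least 200-fold lower number from compound 2 to compound 4 (2.30 log units; beyond the scatter). Among the compounds shown here, none of the earlier compounds formed a pair differing in this one place, so this is the first direct reading of the position, and it shows that this single change can move the read-out a long way. Compound 2 has only a limit of the assay and not a number, so the size of the step is a floor: the limit of > 20 ug/mL in this assay, at which 1 of the 4 values shown sits.

The compounds shown leave open whether hydroxy is the only group that does this on that carbon, or whether an amine or a methoxy group there would do the same. They also leave open how a longer chain beyond that carbon would affect the read-out.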